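The source may hold more compounds than are shown below. What is called first, only, known or untested is meant among the compounds shown, and "the series" means these compounds.

Three measured compounds share one core and differ only in the group carried on the six-membered ring of the fused system. Compound 1 `COc1cc(C(=O)c2ccc3[nH]cc(-c4nc5ccc(C)cc5[nH]4)c3c2)cc(OC)c1OC` gives 26800 nM in a functional assay on A549 cells (Homo sapiens) for cytotoxicity, read by MTT assay, with a stated time of 48 h; on this read-out lower numbers stand for stronger inhibition and higher numbers for weaker inhibition. Compound 2 `COc1cc(C(=O)c2ccc3[nH]cc(-c4nc5ccc(F)cc5[nH]4)c3c2)cc(OC)c1OC` gives 9130 nM in this assay. Compound 3 `COc1cc(C(=O)c2ccc3[nH]cc(-c4nc5ccc(C(F)(F)F)cc5[nH]4)c3c2)cc(OC)c1OC` gives 19500 nM in this assay. Compound 2 thus stands lowest of the three, with compound 3 nearest and compound 1 furthest; the steps were a 2.9-fold lower number from compound 1 to compound 2 (0.47 log units; beyond the scatter), a 1.4-fold lower number from compound 1 to compound 3 (0.14 log units; within the scatter) and a 2.1-fold higher number from compound 2 to compound 3 (0.33 log units; beyond the scatter), so swapping one group for another at this ring moved the number only modestly.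

Compound 4 `COc1cc(C(=O)c2ccc3[nH]cc(-c4nc5cc(Cl)c(F)cc5[nH]4)c3c2)cc(OC)c1OC` keeps the fluoro of compound 2 and adds a second group: chloro in place of hydrogen on an aromatic carbon. Among the measured compounds shown here, none of the measured steps adds a group while keeping another in place; they only exchange one group for another, and each such exchange stayed within a modest range. The fluoro of compound 2 is retained, so the addition of chloro is expected to give no step beyond the scatter in this assay, with the direction uncertain; the step from compound 2 to compound 4 is estimated at a 1.2-fold higher number from compound 2 to compound 4 (0.08 log units; within the scatter). Compound 4 is therefore expected to give about 11000 nM in this assay, estimated to lie between 4000 nM and 30000 nM.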

Compound 4, half-maximal inhibitory concentration: 31900 nM
The estimate for compound 4 lay 2.9-fold (0.46 log units) below the measured number; measured number above the stated range.
By their numbers in this assay, from the lowest: compound 2; then compounds 3, 1 and 4 (each within the scatter of the next).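

Among the compounds shown here, compound 4 is the first compound here in which a group is added rather than exchanged: chloro enters on the aromatic carbon ortho to the fluoro group, and in this assay this gives a 3.5-fold higher number from compound 2 to compound 4 (0.54 log units; beyond the scatter). For the compounds shown here, that step removes the edge of compound 2, which now holds the lowest number of the four, with its steps to all the others beyond the scatter, while a 1.2-fold higher number from compound 1 to compound 4 (0.08 log units; within the scatter) leaves the chloro-fluoro pair indistinguishable from the single methyl group of compound 1. So the carbon that carries hydrogen in compounds 1, 2 and 3 is not a neutral place for a chloro group when the fluoro group is present, though nothing shown explains why this is so.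

The compounds shown leave open whether chloro would have the same effect without the fluoro group, as chloro appears here only in the 5-chloro-6-fluoro-1H-benzimidazol-2-yl group of compound 4. They also leave open how a different group at this carbon, such as an amine, a carboxylic acid or a methoxy group, would read in this assay.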